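The source may report more compounds than this note shows. Statements on the series, on what has been measured and on what is new or still open speak of the compounds shown alone.

Compound 2 `O=C(/C=C/c1cccc(O)c1)c1cccc(-n2cc(-c3ccc(Cl)cc3)[nH]c2=O)c1` stands at the weak end of the three measured compounds in a functional assay on HCC 2998 cells (Homo sapiens) for inhibition (on this read-out lower numbers stand for stronger inhibition of growth and higher numbers for weaker inhibition of growth), giving 13700 nM. Within the data shown here, its parent compound 1 `O=C(/C=C/c1cccc(O)c1)c1cccc(-n2cc(-c3ccccc3)[nH]c2=O)c1` gives 4090 nM, and the only single-point step in the set, a 3.3-fold higher number from compound 1 to compound 2 (0.52 log units; beyond the scatter), is the one that separates them. Among the measured compounds shown here, compound 3 `COc1cc(/C=C/C(=O)c2cccc(-n3cc(-c4cc(OC)c(OC)c(OC)c4)[nH]c3=O)c2)cc(OC)c1OC`, which carries trimethoxyphenyl groups on both ends of the shared core, gives 1920 nM and so sits at the strong end, though it differs from compound 2 in more than one place and no step links them directly.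

Compound 4 `COc1cc(/C=C/C(=O)c2cccc(-n3cc(-c4ccc(Cl)cc4)[nH]c3=O)c2)ccc1O` is obtained from compound 2 by the change (4-hydroxy-3-methoxyphenyl in place of 3-hydroxyphenyl on a double-bonded chain carbon bound to a double-bonded chain carbon). For the measured compounds named here, no measured step bears on exactly this replacement: the one step known, from compound 1 to compound 2, concerns the other aromatic ring, and compound 3 shows only that a more oxygenated pair of rings can go with a lower number. On that slender ground, compound 4 is expected to move little, perhaps toward a somewhat lower number, with a step of a 1.5-fold lower number from compound 2 to compound 4 (0.18 log units; within the scatter) estimated in this assay. Compound 4 is therefore expected to give about 9000 nM, with a range from 3000 nM to 27000 nM.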

Compound 4, concentration for 50% growth inhibition: 1850 nM
Beside the measured number, compound 4's estimate is 4.9-fold (0.69 log units) above it, outside the stated range (below it).
By their numbers in this assay, from the lowest: compounds 4 and 3 (each within the scatter of the next); then compound 1; then compound 2.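

In this assay, the group on the double-bonded chain carbon bound to a double-bonded chain carbon proves to matter a good deal: a 7.4-fold lower number from compound 2 to compound 4 (0.87 log units; beyond the scatter), a change beyond the scatter and opposite in direction to a 3.3-fold higher number from compound 1 to compound 2 (0.52 log units; beyond the scatter), which was made on the other aromatic ring. Among these compounds, the earlier compounds offered no single-place step at this position, so this is the first direct sign that changing the 3-hydroxyphenyl group can lower the number while the chloro substituent stays in place. Nothing available here accounts for the size of this step.

The replacement alters two things at once, since the entering 4-hydroxy-3-methoxyphenyl group both carries a methoxy group and has its hydroxy group elsewhere on the ring, so the compounds shown leave open which of these goes with the lower number and whether the same replacement would lower the number on compound 1 as well. They also leave open how an amine or a carboxylic acid would fare in place of the 3-hydroxyphenyl group.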